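This account rests on a few compounds, and the source may have more. Where it says the series, first, only, none or still open, it means among the compounds named here.

Measured in a physicochemical assay for solubility, at pH 7.4; a higher number here means a more soluble compound, a lower number a less soluble compound:
- Compound 1 `CC[C@H](N)C(=O)N1CCc2c(C)c3c(n2-c2ccc(C(N)=O)c(c2)N[C@@H](C)[C@H](C)C1)CC(C)(C)CC3=O`: > 100 ug/mL (a limit of the assay, not a number)
- Compound 2 `Cc1c2c(n3c1CCN(C(=O)C1(N)CC1)C[C@@H](C)[C@H](C)Nc1cc-3ccc1C(N)=O)CC(C)(C)CC2=O`: 7 ug/mL

Within the data shown here, compound 2, at 7 ug/mL, holds the only actual number so far. Compound 3 `Cc1c2c(n3c1CCN(C(=O)C1(N)CCCC1)C[C@@H](C)[C@H](C)Nc1cc-3ccc1C(N)=O)CC(C)(C)CC2=O` differs from it in one group: 1-aminocyclopentyl in place of 1-aminocyclopropyl on a carbonyl carbon. This puts 1-aminocyclopentyl in place of 1-aminocyclopropyl on a carbonyl carbon. Among the measured compounds shown here, the one measured step at this place is large, an at least 14-fold lower number from compound 1 to compound 2 (1.15 log units; beyond the scatter), and it replaced 1-aminopropyl, which has no ring, with a ring-bearing group. Both groups in the new change carry a ring, so no step beyond the scatter is expected. The expected step is a 1.4-fold lower number from compound 2 to compound 3 (0.15 log units; within the scatter). For compound 3 the estimate is 5 ug/mL, with an expected range of 1.5 ug/mL to 20 ug/mL.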

Compound 3, solubility: 53 ug/mL
For compound 3 the middle estimate is 11-fold (1.03 log units) below the measured one, and the stated range ends below it.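

In this assay, 1-aminocyclopentyl in place of 1-aminocyclopropyl gives a 7.6-fold higher number from compound 2 to compound 3 (0.88 log units; beyond the scatter), so two ring-bearing groups at this place can differ clearly, and the presence of a ring alone does not set the number. Against 1-aminopropyl, which has no ring, 1-aminocyclopentyl gives an at least 1.8-fold lower number from compound 1 to compound 3 (0.27 log units; that floor lies within the scatter), a floor that does not separate the two groups. The value of compound 1 is a limit of the assay, not a number: the limit of > 100 ug/mL in this assay, at which 1 of the 3 values shown sits.

Among these compounds, with only two ring sizes, it remains open whether the number follows ring size, which 1-aminocyclohexyl would test. The reason for the step also remains unknown.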